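Octylsulfonamido-biphenyl acids: chloro-to-butyl step on two cores

The source may hold more compounds than are shown below. What is called first, only, known or untested is meant among the compounds shown, and "the series" means these compounds.

Measured so far:
compound 1, `CCCCCCCCS(=O)(=O)Nc1cc(-c2ccc(Cl)cc2)ccc1C(=O)O`, 18100 nM
compound 2, `CCCCCCCCS(=O)(=O)Nc1cc(-c2ccc(CCCC)cc2)ccc1C(=O)O`, 15700 nM
compound 3, `CCCCCCCCS(=O)(=O)Nc1ccc(-c2ccc(Cl)cc2)cc1C(=O)O`, 9200 nM

All three were read in an assay on mitochondria (strain BALB/c) for inhibition of glycerol-3-phosphate acyltransferase 1, mitochondrial (Mus musculus), read by scintillation counting, with a stated time of 10 min; on this read-out higher numbers stand for weaker inhibition and lower numbers for stronger inhibition. Compound 1 and compound 2 share one core and differ only at the far ring, where the change butyl in place of chloro on an aromatic carbon gives a 1.2-fold lower number from compound 1 to compound 2 (0.06 log units; within the scatter). Compound 3 carries the same atoms as compound 1 joined differently; the difference between the two cores is not broken down here. In this assay compound 3 gives 9200 nM, and its gap to compound 1 and to compound 2 lies within the scatter, so no order among the three is claimed.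

Compound 4, `CCCCCCCCS(=O)(=O)Nc1ccc(-c2ccc(CCCC)cc2)cc1C(=O)O`, has not been measured. It relates to compound 3 as compound 2 relates to compound 1: the change (butyl in place of chloro on an aromatic carbon), at the same place on the far ring. Going by the values given here, with only one earlier instance of this change, on the other core, the expectation rests on that single step: the change from compound 1 to compound 2 stayed within the scatter, so a step of similar size is expected here, a 1.2-fold lower number from compound 3 to compound 4 (0.06 log units; within the scatter). On that basis compound 4 is estimated at 8000 nM in this assay, with a range from 4000 nM to 18000 nM. The wide range reflects that the transfer of a single within-scatter step to a second core is untested among these compounds.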

Compound 4, half-maximal inhibitory concentration: 9000 nM
For compound 4 the middle estimate is 1.1-fold (0.05 log units) below the measured one, and the stated range covers the measured number.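

In this assay, butyl in place of chloro on the second core gives a 1.0-fold lower number from compound 3 to compound 4 (0.01 log units; within the scatter), so on this core too the change stays within the scatter. Set side by side, the two steps do not differ: the same change on two cores in this assay, a 1.2-fold lower number (0.06 log units; within the scatter) from compound 1 to compound 2 and a 1.0-fold lower number (0.01 log units; within the scatter) from compound 3 to compound 4, 1.1-fold (0.05 log units) apart, within the scatter of two such steps. This shows that, on these two cores and in this one assay, the exchange of chloro for butyl leaves the number within the scatter both times; it does not show that a step beyond the scatter would carry over in the same way, nor that the same result would hold on any further core, and with only two instances, neither of them a readable effect, it supports no general rule for the series.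

At the far ring only chloro and butyl are shown, so the results for other groups at that place, such as an amine, a methoxy group or a longer chain like octyl, remain open. Also open, from the compounds shown here alone, is how the numbers would respond at other parts of the molecule, for example a decyl chain in place of the octyl chain on the sulfonyl group, or a tetrazole in place of the carboxylic acid.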